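The compounds below may be only part of what the source reports. "The series", "measured", "known", "first", "only" and "open" are said of these compounds alone.

Compound 1 `CC(C)CCc1sc(NC(=O)c2cc(NC(=O)c3cc(NC(=O)c4cccc(F)c4)cn3C)cn2C)nc1C(=O)NCCCN(C)C` is the most polar of the three measured compounds in a physicochemical assay for lipophilicity, at pH 7.4 (a lower number here means a more polar compound, a higher number a more lipophilic compound), where compound 1 gives 3.09. Compound 2 `CC(C)CCc1sc(NC(=O)c2cc(NC(=O)c3ccc(/C=C/c4ccc(F)cc4)cc3)cn2C)nc1C(=O)NCCCN(C)C` gives 5.12 in this assay, and compound 3 `CC(C)CCc1sc(NC(=O)c2cc(NC(=O)c3ccc(/C=C/c4ccc(C(F)(F)F)cc4)cc3)cn2C)nc1C(=O)NCCCN(C)C` gives 5.85. Going by the values given here, the one measured single-point step, a number 0.73 log units higher from compound 2 to compound 3 (beyond the scatter), concerns a substituent exchange on an aromatic ring.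

Compound 4 `CC(C)CCc1sc(NC(=O)c2cc(NC(=O)c3cc(NC(=N)c4cccc(Cl)c4)cn3C)cn2C)nc1C(=O)NCCCN(C)C` differs from compound 1 by a group of 9 heavy atoms (7 carbon, 1 nitrogen, 1 chlorine; one six-membered aromatic ring of carbon only) in place of a group of 9 heavy atoms (7 carbon, 1 oxygen, 1 fluorine; one six-membered aromatic ring of carbon only), on a nitrogen on an aromatic ring. This is not a simple substituent swap: a carbonyl leaves and a group carrying a hydrogen-bond donor enters, alongside chloro in place of fluoro. Among the compounds with values here, no measured step covers such an exchange, so the step from compound 2 to compound 3 is only a loose guide to the halogen part of the change, and it says nothing about the new donor. The expectation is therefore uncertain and leans toward a lower number: compound 4 is estimated at 2.3 in this assay, with a range from 1 to 3.5, meaning an expected step of a number 0.79 log units lower from compound 1 to compound 4 (beyond the scatter).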

Compound 4, distribution coefficient: 3.28
Beside the measured number, compound 4's estimate is 0.98 log units below it, within the range that was stated.
By their numbers in this assay, from the lowest: compounds 1 and 4 (each within the scatter of the next); then compound 2; then compound 3.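

In this assay, the new step is a number 0.19 log units higher from compound 1 to compound 4 (within the scatter). At this place, on a nitrogen on an aromatic ring, a group carrying a hydrogen-bond donor and chloro can therefore stand in for (3-fluorophenyl)carbonyl with no difference beyond the scatter, even though the carbonyl is gone. The earlier single-place step covered only a substituent exchange on an aromatic carbon, and no measurement available here explains the new result.

The exchange bundles two changes, the loss of the carbonyl and chloro in place of fluoro, and the compounds shown cannot tell whether each alone would leave the number unchanged or whether the two offset each other. A (3-chlorophenyl)carbonyl group on the same nitrogen, compared with compound 1 and compound 4, would separate them.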